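Phenyl for chloro on the ring of compound 2

This account rests on a few compounds, and the source may have more. Where it says the series, first, only, none or still open, it means among the compounds named here.

Two compounds of the series carry a number in an assay on HEK293 cells for displacement of a labelled ligand from Neuronal acetylcholine receptor; alpha3/beta4 (Homo sapiens), read by scintillation counting and radioligand binding, with a stated time of 5 min; a higher number here means a weaker inhibitor, a lower number a stronger inhibitor. Compound 1 `Clc1ccc(N2CC3CC(C2)N3)cn1` gives 0.2 nM in this assay. Compound 2 `Clc1cncc(N2CC3CC(C2)N3)c1` gives 2.6 nM in this assay. Among the measured compounds shown here, of the two values the one of compound 2 is the higher, and the gap to compound 1, the only neighbour with a number, lies beyond the usual scatter of this assay; the two differ in where the ring nitrogen and the chloro sit, and no single-place step between them has been computed.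

Compound 3 `c1ccc(-c2cncc(N3CC4CC(C3)N4)c2)cc1` is the next member and has no number yet. It differs from compound 2 in one place: phenyl in place of chloro on an aromatic carbon, two atoms from the ring nitrogen. For the measured compounds named here, no measured pair shows what such a swap does here, so the expected step is small, either way, and not clearly beyond the scatter; if anything a slightly lower number is expected. For compound 3 the estimate in this assay is 2 nM, with a range from 0.3 nM to 15 nM. This estimate means a step of a 1.3-fold lower number from compound 2 to compound 3 (0.11 log units; within the scatter).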

Compound 3, inhibition constant: 6.1 nM
The estimate for compound 3 lay 3.1-fold (0.48 log units) below the measured number; the range from low to high includes it.
By their numbers in this assay, from the lowest: compound 1; then compound 2; then compound 3.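

In this assay the place two atoms from the ring nitrogen takes phenyl in place of chloro at a modest but real cost, as the swap gives a 2.3-fold higher number from compound 2 to compound 3 (0.37 log units; beyond the scatter) and leaves the series with its first measured step. The entering group brings six heavy atoms and a whole aromatic ring where one chlorine stood, yet compound 3 still gives 6.1 nM in this assay, so a far larger group on this aromatic carbon is compatible with a number of this order and does not remove binding. Nothing at hand gives a reason for the size or direction of this step.

Open, on these data alone, is how the response runs across groups of other sizes and kinds at this place, for example a methyl, a methoxy or a primary amine, and whether a substituted phenyl or a carboxylic acid would move the number further up or bring it back down. Also open, as far as these compounds go, is whether phenyl in place of chloro gives a similar step on the ring of compound 1, where the chloro and the ring nitrogen are arranged differently.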